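Swapping a Ring Amine for a Methylphenyl Group

This account rests on a few compounds, and the source may have more. Where it says the series, first, only, none or still open, it means among the compounds named here.

Measured compounds:
Compound 1, `C/N=C(/NC#N)NCCCCn1nc(N(C)C)ccc1=O`: 26.3%
Compound 2, `C/N=C(/NC#N)NCCCCn1nc(N2CCCC2)ccc1=O`: -1%
Compound 3, `CCC/N=C(/NC#N)NCCCCCn1nc(-c2ccccc2)ccc1=O`: 27.5%

All three were tested in a functional assay on the whole organism with Rattus norvegicus as the target, at a dose of 100 mg/kg; a lower number here means less inhibition, a higher number more inhibition at the dose given (going by the name of the read-out). Compound 2 stands lowest of the three numbers; its nearest neighbour is compound 1, and compound 3 lies furthest from it, both gaps being beyond the usual scatter. Among the measured compounds shown here, the single one-point step among the measured compounds is a number 27.3 percentage points lower from compound 1 to compound 2 (beyond the scatter), which shows that the group on this aromatic carbon of the shared core can move the read-out by a modest amount.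

Compound 4, `C/N=C(/NC#N)NCCCCn1nc(-c2ccc(C)cc2)ccc1=O`, is not yet measured. It differs from compound 2 as follows: 4-methylphenyl in place of pyrrolidin-1-yl on an aromatic carbon. For the measured compounds named here, no measured step covers an aromatic group entering at this position, so the step from compound 1 to compound 2 is only an indirect guide; it suggests that leaving the pyrrolidin-1-yl group may well move the number back upward, toward the level of compound 1 and compound 3. Compound 4 is therefore expected to show a step of a number 26 percentage points higher from compound 2 to compound 4 (beyond the scatter), with an estimated value of 25%, likely between 5% and 45%.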

Compound 4, a percentage reported as inhibition, in the whole organism at one dose (the size of the read-out at that dose, not a potency): 45.7%
Beside the measured number, compound 4's estimate is 20.7 percentage points below it; measured number above the stated range.
By their numbers in this assay, from the lowest: compound 2; then compounds 1 and 3 (each within the scatter of the next); then compound 4.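

Compound 1 and compound 2 carry amines at this position of the shared core, and compound 4 shows that a carbon-only aromatic ring can sit there too. In this assay, 4-methylphenyl in place of pyrrolidin-1-yl gives a number 46.7 percentage points higher from compound 2 to compound 4 (beyond the scatter) and 4-methylphenyl in place of dimethylamino gives a number 19.4 percentage points higher from compound 1 to compound 4 (beyond the scatter) so the rise holds against both amines rather than only the lower of the two. Nothing available explains why this change raises the number.

On these data alone, what a plain phenyl group would give on this same chain remains open, which leaves the part played by the methyl group unsettled. So does the effect of a 4-chlorophenyl group or a morpholine ring at this position.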